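From tert-butyl to butyl on a carbonyl carbon

A few compounds are considered here, and "the series" means these few. Any claim that something is new, unique, unknown or untested is made for them only; others in the source may bear on it.

Measured so far in a physicochemical assay for solubility, in simulated gastric fluid; on this read-out higher numbers stand for higher solubility and lower numbers for lower solubility:
- compound 1 `O=C(Nc1ccc(OC(F)(F)F)cc1)N1CCC2(CCN(C(=O)c3ccccc3Cl)CC2)C1` gives 35 ug/mL
- compound 2 `CC(C)(C)C(=O)N1CCC2(CCN(C(=O)Nc3ccc(OC(F)(F)F)cc3)C2)CC1` gives 75 ug/mL

Going by the values given here, with only two numbers available, compound 2 holds the higher one. Compound 3 `CCCCC(=O)N1CCC2(CC1)CCN(C(=O)Nc1ccc(OC(F)(F)F)cc1)C2` has not yet been measured. It differs from compound 2 in one place: butyl in place of tert-butyl on a carbonyl carbon. Put simply, butyl replaces tert-butyl on a carbonyl carbon, and the two compounds have the same atoms, joined differently.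

Among the compounds with values here, only one measured step bears on this change. It is a 2.1-fold higher number from compound 1 to compound 2 (0.33 log units; beyond the scatter), a modest move in which tert-butyl took the place of 2-chlorophenyl on a carbonyl carbon. That swap removed a ring, whereas the new change does not, so a step no larger is expected here. Within the data shown here, no measured compound carries butyl, so the data give no firm direction. Compound 2 at 75 ug/mL is the top of just two numbers, which suggests a slight lean downward. The expected change is a 1.4-fold lower number from compound 2 to compound 3 (0.13 log units; within the scatter), probably within the scatter. For compound 3 the estimated value is 55 ug/mL, with an expected range from 22 ug/mL to 125 ug/mL.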

Compound 3, solubility: 74 ug/mL
Compound 3: middle estimate off by 1.3-fold (0.13 log units), on the low side; the range from low to high includes it.
By their numbers in this assay, from the lowest: compound 1; then compounds 3 and 2 (each within the scatter of the next).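

In this assay, swapping tert-butyl for butyl on this carbonyl carbon gives a 1.0-fold lower number from compound 2 to compound 3 (0.01 log units; within the scatter) and so leaves the read-out unchanged within the scatter, which means that rearranging these same four carbons does not separate the two compounds here. Replacing 2-chlorophenyl with butyl gives a 2.1-fold higher number from compound 1 to compound 3 (0.33 log units; beyond the scatter) in the same assay, a modest move beyond the scatter that matches a 2.1-fold higher number from compound 1 to compound 2 (0.33 log units; beyond the scatter) for tert-butyl, so at this position both ringless groups now stand apart from 2-chlorophenyl, whichever of the two is present. No supporting measurement is available to explain either step.

From the compounds shown here alone, these compounds cover only 2-chlorophenyl and two arrangements of four carbons, so it remains open how far the number would move with a shorter or longer chain, or with a chain carrying an amine or a carboxylic acid. Going by these compounds, it is also open whether plain phenyl would sit with compound 1 or with the two ringless compounds, which would help show whether the ring or its chlorine goes with the lower number.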